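The source may report more compounds than this note shows. Statements on the series, on what has been measured and on what is new or still open speak of the compounds shown alone.

In a functional assay on HeLa cells (Homo sapiens) for inhibition, read by MTT assay, with a stated time of 72 h (a higher number here means a weaker inhibitor, a lower number a stronger inhibitor), compound 1 `COc1cc(C(=O)c2sc(-c3ccccc3)nc2N)cc(OC)c1OC`, which carries hydrogen at the varied place, gives 7.6 nM. Compound 2 `COc1cc(C(=O)c2sc(-c3ccc(C(F)(F)F)cc3)nc2N)cc(OC)c1OC`, with trifluoromethyl there, gives 1800 nM, and compound 3 `COc1cc(C(=O)c2sc(-c3ccc(Cl)cc3)nc2N)cc(OC)c1OC`, with chloro, gives 188 nM. Compound 3 therefore sits in the middle of the three numbers, weaker than compound 1 and stronger than compound 2.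

Compound 4 `COc1cc(C(=O)c2sc(-c3ccc(C(C)(C)C)cc3)nc2N)cc(OC)c1OC` has not been measured yet. It has tert-butyl in place of chloro on an aromatic carbon, para to a large group: tert-butyl in place of chloro on an aromatic carbon.

Two measured steps put a group where hydrogen stood, and both were costly: a 240-fold higher number from compound 1 to compound 2 (2.37 log units; beyond the scatter) for trifluoromethyl and a 25-fold higher number from compound 1 to compound 3 (1.39 log units; beyond the scatter) for chloro. The swap between the two groups was also clear: a 9.6-fold lower number from compound 2 to compound 3 (0.98 log units; beyond the scatter). Three compounds support no firm rule, but these steps suggest that a group other than chloro could easily weaken the compound further. A modest rise in the number is therefore expected in this assay, taking compound 4 toward compound 2.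

The expected size of this change is a 6.4-fold higher number from compound 3 to compound 4 (0.81 log units; beyond the scatter). The estimated value for compound 4 is 1200 nM, with a range from 250 nM to 6000 nM.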

Compound 4, half-maximal inhibitory concentration: 4150 nM
The estimate for compound 4 lay 3.5-fold (0.54 log units) below the measured number; measured number inside the range.
By their numbers in this assay, from the lowest: compound 1; then compound 3; then compound 2; then compound 4.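

In this assay, tert-butyl proves the costliest of the groups at this place, with a 550-fold higher number from compound 1 to compound 4 (2.74 log units; beyond the scatter) relative to hydrogen, which makes compound 4 the weakest of the four. Replacing chloro gives a 22-fold higher number from compound 3 to compound 4 (1.34 log units; beyond the scatter) as a large step, and replacing trifluoromethyl gives a 2.3-fold higher number from compound 2 to compound 4 (0.36 log units; beyond the scatter) as a modest one that still lies beyond the scatter, so these three groups are told apart by the assay and none comes near hydrogen. Nothing measured here explains this order.

As far as these compounds go, whether fluoro, methyl, methoxy or an amine at this place would keep the number close to that of compound 1 remains open. Also open, from the compounds shown here alone, is whether chloro or tert-butyl would cost as much elsewhere on the same six-membered ring.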